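This account rests on a few compounds, and the source may have more. Where it says the series, first, only, none or still open, it means among the compounds named here.

Measured so far in a functional assay on SK-BR-3 cells (Homo sapiens) for antiproliferative activity, read by MTT assay, with a stated time of 72 h; on this read-out lower numbers stand for stronger inhibition and higher numbers for weaker inhibition:
- compound 1 `CCN1CCN(c2cc(C)c3cc(NC(=O)c4cccnc4)ccc3n2)CC1`: 10600 nM
- compound 2 `CCN1CCN(c2cc(C)c3cc(NC(=O)c4cc5ccccc5[nH]4)ccc3n2)CC1`: 2550 nM
- compound 3 `CCN1CCN(c2cc(C)c3cc(NC(=O)c4ccccc4)ccc3n2)CC1`: 18400 nM

Compound 3 carries the highest number of the three. Its nearest neighbour is compound 1, with a 1.7-fold higher number from compound 1 to compound 3 (0.24 log units; within the scatter); that gap is within the scatter, so no order can be read between these two. The furthest is compound 2, with a 7.2-fold higher number from compound 2 to compound 3 (0.86 log units; beyond the scatter), a gap beyond the scatter.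

Compound 4 `CCN1CCN(c2cc(C)c3cc(NC(=O)c4ccc(Br)cc4)ccc3n2)CC1` differs from compound 3 by bromo in place of hydrogen on an aromatic carbon; the bromo sits para to a large group. For the measured compounds named here, none of the measured steps bears directly on this change: each of them exchanges the whole ring on the carbonyl carbon (a 4.2-fold lower number from compound 1 to compound 2 (0.62 log units; beyond the scatter), a 1.7-fold higher number from compound 1 to compound 3 (0.24 log units; within the scatter), a 7.2-fold higher number from compound 2 to compound 3 (0.86 log units; beyond the scatter)), and none keeps a ring in place while adding a substituent to it. The series therefore gives no guide to a single bromo on a retained phenyl, and the default expectation in this assay is a step no larger than the scatter, in no settled direction, with a wide range to reflect the lack of precedent.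

For compound 4 the expected value is 14000 nM, within 5000 nM to 40000 nM. The step this estimate means is a 1.3-fold lower number from compound 3 to compound 4 (0.12 log units; within the scatter), expected to stay within the scatter.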

Compound 4, half-maximal inhibitory concentration: 6310 nM
For compound 4 the middle estimate is 2.2-fold (0.35 log units) above the measured one; the range from low to high includes it.
By their numbers in this assay, from the lowest: compound 2; then compounds 4, 1 and 3 (each within the scatter of the next, the first and the last beyond it).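

In this assay, for the compounds shown here, bromo in place of hydrogen on the retained phenyl, para to a large group, is the first change that keeps the ring on the carbonyl carbon and adds a substituent to it, and it gives a 2.9-fold lower number from compound 3 to compound 4 (0.46 log units; beyond the scatter), so this place on the phenyl responds to a single heavy atom. The bromo brings the benzamide level with the pyridin-3-yl amide, with a 1.7-fold lower number from compound 1 to compound 4 (0.23 log units; within the scatter), but the 1H-indol-2-yl amide keeps its lead, with a 2.5-fold higher number from compound 2 to compound 4 (0.39 log units; beyond the scatter), so 4-bromophenyl does not match that ring. Nothing at hand on the properties of these compounds accounts for the step.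

Still open, going by these compounds, is whether the step belongs to bromo itself or would also appear with chloro, methyl or methoxy at the same place. Also open, on these data alone, is whether a bromo carried on the 1H-indol-2-yl ring or the pyridin-3-yl ring would shift the number as it does on the phenyl, or whether the effect is confined to the phenyl.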